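Ether to Ester at the Selenocyanate Chain

The source may hold more compounds than are shown below. What is called first, only, known or untested is meant among the compounds shown, and "the series" means these compounds.

Of the compounds shown here, two sharing one core have been tested in a functional assay on MDA-MB-231 cells (Homo sapiens) for inhibition, read by MTT assay, with a stated time of 48 h; on this read-out higher numbers stand for weaker inhibition and lower numbers for stronger inhibition. Compound 1 `COc1ccc(N(C)c2nc(C)nc3ccccc23)cc1C(=O)OCCCCC[Se]C#N` gives 851 nM. Compound 2 `COc1ccc(N(C)c2nc(C)nc3ccccc23)cc1OCCCCC[Se]C#N` gives 4410 nM, the higher of the two numbers, and its gap to compound 1 lies beyond the usual scatter. Compound 3 `COc1ccc(N(C)c2nc(C)nc3ccccc23)cc1C(=O)OCCCC[Se]C#N` differs from compound 2 at one place: a group of 10 heavy atoms (6 carbon, 1 nitrogen, 2 oxygen, 1 selenium; no ring) in place of a group of 9 heavy atoms (6 carbon, 1 nitrogen, 1 oxygen, 1 selenium; no ring), on an aromatic carbon. Within the data shown here, no measured step of this kind exists. Because compound 1 gives 851 nM with a similar chain, compound 3 is expected to show a downward step a 3.7-fold lower number from compound 2 to compound 3 (0.57 log units; beyond the scatter) beyond the scatter. Compound 3 is estimated at 1200 nM, within 400 nM to 3500 nM.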

Compound 3, half-maximal inhibitory concentration: 554 nM
Compound 3: the middle estimate sits 2.2-fold (0.34 log units) above what was measured; the range from low to high includes it.
By their numbers in this assay, from the lowest: compounds 3 and 1 (each within the scatter of the next); then compound 2.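

In this assay, replacing the ether-linked chain with the ester-linked chain on this aromatic carbon gives stronger inhibition, with an 8.0-fold lower number from compound 2 to compound 3 (0.90 log units; beyond the scatter). Between the two ester compounds, the difference on the saturated chain gives a 1.5-fold lower number from compound 1 to compound 3 (0.19 log units; within the scatter), so this chain difference does not separate them. No measurement here explains either step.

As far as these compounds go, whether an amide link in place of the ester would perform similarly remains open. So does the effect of a longer chain, or of a thiocyanate in place of the selenocyanate.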